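Enaminone series: swapping chloro for hydroxy on the aniline

The compounds below may be only part of what the source reports. "The series", "measured", "known", "first", "only" and "open" are said of these compounds alone.

Two members of this series have numbers in a functional assay on A549 cells (Homo sapiens) for antiproliferative activity, read by MTT assay, with a stated time of 48 h; on this read-out higher numbers stand for weaker inhibition and lower numbers for stronger inhibition. Compound 1 `COc1ccc(-c2nn(-c3ccccc3)cc2C(=O)/C=C\Nc2ccc(Cl)cc2)cc1` gives 2970 nM in this assay. Compound 2 `COc1cc(-c2nn(-c3ccccc3)cc2C(=O)/C=C\Nc2ccc(Cl)cc2)cc(OC)c1OC` gives 8670 nM in this assay, the highest of the two numbers, and the number for compound 1 is lower by a margin beyond the usual scatter. Within the data shown here, no single-change step between these two is on hand, so only the two values themselves are compared.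

Compound 3 `COc1cc(-c2nn(-c3ccccc3)cc2C(=O)/C=C\Nc2ccc(O)cc2)cc(OC)c1OC` carries the change (hydroxy in place of chloro on an aromatic carbon). Among the measured compounds shown here, nothing in the measured pair speaks to this change, and no step of the same kind has been measured. The expectation is therefore a step of modest size, if any, with no clear direction beyond the scatter, and the estimated step from compound 2 onward is a 1.2-fold higher number from compound 2 to compound 3 (0.06 log units; within the scatter). In this assay compound 3 is expected to give about 10000 nM, within a range from 3500 nM to 30000 nM.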

Compound 3, half-maximal inhibitory concentration: 3160 nM
Beside the measured number, compound 3's estimate is 3.2-fold (0.50 log units) above it; the measured number lies below the stated range.
By their numbers in this assay, from the lowest: compounds 1 and 3 (each within the scatter of the next); then compound 2.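

Compound 1 and compound 2 both carry the (4-chlorophenyl)amino group, so they gave no reading on this position. Exchanging it for (4-hydroxyphenyl)amino in this assay gives a 2.7-fold lower number from compound 2 to compound 3 (0.44 log units; beyond the scatter), a first sign that this aromatic carbon, para to a large group, responds to substitution and that chloro is not needed there to keep this level of antiproliferative activity. This rests on a single pair on one core, and nothing on hand accounts for the size or direction of the step.

The compounds shown leave open whether the same exchange gives a step of similar size on the core of compound 1, which keeps the 4-chlorophenyl group. They also leave open how an amine or a carboxylic acid at this place would read out.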